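The source may hold more compounds than are shown below. What is called first, only, known or untested is meant among the compounds shown, and "the series" means these compounds.

Working notes on the series. Compound 1 `CCCNc1cc(Oc2ccc(NC(=O)Nc3cccc(C(F)(F)F)c3)cc2)ncn1` gives 32 nM in an assay on isolated protein for inhibition of serine/threonine-protein kinase TNNI3K (Homo sapiens); a lower number here means a stronger inhibitor, a higher number a weaker inhibitor. Compound 2 `Cc1cc(Oc2ccc(NC(=O)Nc3cccc(C(F)(F)F)c3)cc2)ncn1` gives 160 nM in this assay, and compound 3 `CN(C)c1cc(Oc2ccc(NC(=O)Nc3cccc(C(F)(F)F)c3)cc2)ncn1` gives 2500 nM. Compound 3 has the highest number of the three: the step of a 78-fold higher number from compound 1 to compound 3 (1.89 log units; beyond the scatter) and the step of a 16-fold higher number from compound 2 to compound 3 (1.19 log units; beyond the scatter) both run to it, and the step of a 5.0-fold higher number from compound 1 to compound 2 (0.70 log units; beyond the scatter) is the smallest of the three steps.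

Compound 4 `O=C(Nc1ccc(Oc2ccncc2)cc1)Nc1cccc(C(F)(F)F)c1` differs from compound 3 by pyridin-4-yl in place of 6-(dimethylamino)pyrimidin-4-yl on an oxygen on an aromatic ring. Among the measured compounds shown here, no measured step swaps one ring for another at this oxygen; the three measured steps only change the group on the aromatic carbon of the core of compound 3, and they show that changes there move this assay by modest to large amounts, always with compound 3 at the weak end. Given that compound 3 sits at the weak end of the series on 2500 nM, compound 4 is expected to return toward the range of compound 2, an estimated step of an 8.3-fold lower number from compound 3 to compound 4 (0.92 log units; beyond the scatter) in this assay. Compound 4 is therefore expected to give about 300 nM, in a range from 50 nM to 2000 nM.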

Compound 4, half-maximal inhibitory concentration: 50 nM
Estimate against measurement, compound 4: 6.0-fold (0.78 log units) above; the range from low to high includes it.
By their numbers in this assay, from the lowest: compounds 1 and 4 (each within the scatter of the next); then compound 2; then compound 3.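

At this oxygen on an aromatic ring, changing the ring itself moves the number as far as the group changes on the aromatic carbon did: pyridin-4-yl in place of 6-(dimethylamino)pyrimidin-4-yl gives (a 50-fold lower number from compound 3 to compound 4 (1.70 log units; beyond the scatter)) in this assay, and pyridin-4-yl in place of 6-methylpyrimidin-4-yl gives (a 3.2-fold lower number from compound 2 to compound 4 (0.51 log units; beyond the scatter)). Against 6-(propylamino)pyrimidin-4-yl, the same swap gives (a 1.6-fold higher number from compound 1 to compound 4 (0.19 log units; within the scatter)). Within these four compounds, then, the propylamino group is not required for a number at this level, since pyridin-4-yl alone on the oxygen matches it within the scatter.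

Still open, on these data alone, is whether propylamino or a longer amine chain on the pyridin-4-yl ring would add to the number seen for compound 4, and how a plain phenyl ring would behave on this oxygen. No measured evidence here accounts for the size of these steps.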